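This account rests on a few compounds, and the source may have more. Where it says the series, first, only, none or still open, it means among the compounds named here.

In a functional assay on NCI-H460 cells (Homo sapiens) for antiproliferative activity, with a stated time of 72 h (on this read-out higher numbers stand for weaker inhibition and lower numbers for stronger inhibition), three compounds built on one shared core have been measured. Compound 1 `Nc1ncnn2c([C@@H]3O[C@H](CO)[C@@H](O)[C@H]3O)cc(C#Cc3cccs3)c12`, which carries a 2-(thiophen-2-yl)ethynyl group, gives 26600 nM. Compound 2 `Nc1ncnn2c([C@@H]3O[C@H](CO)[C@@H](O)[C@H]3O)cc(C#Cc3ccccc3)c12`, which carries a 2-phenylethynyl group, gives 38500 nM. Swapping the end group on the triple bond gives a 1.4-fold higher number from compound 1 to compound 2 (0.16 log units; within the scatter).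

Compound 3 `Nc1ncnn2c([C@@H]3O[C@H](CO)[C@@H](O)[C@H]3O)cc(-c3ccccc3)c12` has a plain phenyl at the same place and gives > 100000 nM, which is a limit and not a number. This is the limit of > 100000 nM in this assay, at which 1 of the 3 values shown sits. Reaching it from the two alkynes means an at least 3.7-fold higher number from compound 1 to compound 3 (0.57 log units; beyond the scatter) and an at least 2.5-fold higher number from compound 2 to compound 3 (0.41 log units; beyond the scatter), so compound 3 stands at the weak end of this small set.

Compound 4 `Nc1ncnn2c([C@@H]3O[C@H](CO)[C@@H](O)[C@H]3O)cc(-c3ccc(F)cc3)c12` differs from compound 3 by fluoro in place of hydrogen on an aromatic carbon. Within the data shown here, no measured compound tests this change directly. The closest guide is the swap of ring at the end of the group in compound 2, a 1.4-fold higher number from compound 1 to compound 2 (0.16 log units; within the scatter), which stayed small. The two larger steps removed the whole triple bond, and nothing of that kind happens here.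

No step beyond the scatter is therefore expected, and the expected step is a number no higher from compound 3 to compound 4 (the limit leaves the size open). A second limit would be no surprise. For compound 4 the estimated value is 100000 nM, with an expected range from 50000 nM to 200000 nM.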

Compound 4, half-maximal inhibitory concentration: 55500 nM
The estimate for compound 4 lay 1.8-fold (0.26 log units) above the measured number, and the stated range covers the measured number.
By their numbers in this assay, from the lowest: compounds 1, 2 and 4 (each within the scatter of the next, the first and the last beyond it). At a limit, above all of these: compound 3.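

In this assay, compound 4 shows that a ring set directly on the shared core, with no triple bond, can still give a measured number rather than a limit, which compound 3 alone did not show. Adding the fluoro gives an at least 1.8-fold lower number from compound 3 to compound 4 (0.25 log units; that floor lies within the scatter), and the true size of this step stays open because compound 3 has only a limit: the limit of > 100000 nM in this assay, at which 1 of the 4 values shown sits. Set against the two alkynes, the picture splits, with a 1.4-fold higher number from compound 2 to compound 4 (0.16 log units; within the scatter), but a 2.1-fold higher number from compound 1 to compound 4 (0.32 log units; beyond the scatter), so losing the triple bond costs little against the phenyl alkyne and a modest amount against the thiophene alkyne once the fluoro is present.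

On these data alone, what remains open is whether fluoro is special at this spot or whether another small group para to the large group, such as chloro, methoxy or an amine, would also lift the ring clear of the limit. Also open, as far as these compounds go, is what a 4-fluorophenyl would do at the end of the triple bond, where it would take the place of the phenyl in compound 2.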